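Ester chain variation on the deschloro-fluoro cyclohexenedicarboximide benzoate

The source may hold more compounds than are shown below. What is called first, only, known or untested is meant among the compounds shown, and "the series" means these compounds.

Measured compounds: compound 1 `CCOC(=O)c1cc(N2C(=O)C3=C(CCCC3)C2=O)c(F)cc1Cl` gives 57.5 nM in a functional assay on the whole organism for inhibition, with Scenedesmus acutus as the target; a higher number here means a weaker inhibitor, a lower number a stronger inhibitor; compound 2 `CCOC(=O)c1cc(N2C(=O)C3=C(CCCC3)C2=O)ccc1Cl` gives 1910 nM; compound 3 `CCCCOC(=O)c1cc(N2C(=O)C3=C(CCCC3)C2=O)c(F)cc1Cl` gives 126 nM.

Compound 2 has the highest number of the three, beyond the scatter from both others, with a 33-fold higher number from compound 1 to compound 2 (1.52 log units; beyond the scatter) marking its distance from compound 1.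

Compound 4 `CC(C)COC(=O)c1cc(N2C(=O)C3=C(CCCC3)C2=O)ccc1Cl` is not yet measured. It differs from compound 2 by isopropyl in place of methyl on a saturated chain carbon bound to an oxygen next to a carbonyl group, that is, ethoxycarbonyl to isobutoxycarbonyl. Among the compounds with values here, the one measured step on the chain at this place is a 2.2-fold higher number from compound 1 to compound 3 (0.34 log units; beyond the scatter), a modest rise in the number. Compound 4 is therefore expected to show a similar modest rise, a 2.0-fold higher number from compound 2 to compound 4 (0.30 log units; within the scatter), with the estimate for compound 4 at 3800 nM within a range from 1500 nM to 9500 nM.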

Compound 4, half-maximal inhibitory concentration: 977 nM
Estimate against measurement, compound 4: 3.9-fold (0.59 log units) above; the whole stated range lies above it.
By their numbers in this assay, from the lowest: compound 1; then compound 3; then compounds 4 and 2 (each within the scatter of the next).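

In this assay, the ethoxycarbonyl to isobutoxycarbonyl change gives a 2.0-fold lower number from compound 2 to compound 4 (0.29 log units; within the scatter), so compound 2 and compound 4 cannot be told apart at this position. The step beyond the scatter seen with the fluoro compounds, a 2.2-fold higher number from compound 1 to compound 3 (0.34 log units; beyond the scatter), therefore does not hold as a general rise for larger ester chains; compound 4 goes against it. Nothing at hand bears on the reason for this difference.

Still open, as far as these compounds go, is whether isobutoxycarbonyl behaves the same way with fluoro on the aromatic carbon. From the compounds shown here alone, a carboxylic acid in place of the ester also remains open.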